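The source may hold more compounds than are shown below. What is called first, only, known or untested is meant among the compounds shown, and "the series" means these compounds.

Working notes on the arylpiperazine series.

Compound 1 `c1ccc(N2CCN(CCCCOc3ccc4c(c3)CCC4)CC2)cc1` is the reference point; in a functional assay on the whole organism for inhibition, with Mus musculus as the target, at a dose of 25 mg/kg by the oral route (on this read-out higher numbers stand for more inhibition at the one dose given (going by the name of the read-out) and lower numbers for less inhibition), compound 1 gives 50%. Compound 2 `c1ccc(N2CCN(CCCOc3cccc4c3CCC4)CC2)cc1` gives 33% in this assay, and compound 3 `Fc1ccc(N2CCN(CCCOc3cccc4c3CCC4)CC2)cc1` gives 25%. How the core of compound 1 differs from the core of compound 2 is not broken down here.

The one counted step among the measured compounds is a number 8 percentage points lower from compound 2 to compound 3 (within the scatter), the change being fluoro in place of hydrogen on an aromatic carbon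

Compound 4 `Fc1cc2c(cc1OCCCCN1CCN(c3ccccc3)CC1)CCC2` differs from compound 1 by fluoro in place of hydrogen on an aromatic carbon

Going by the values given here, this is the same kind of change as the one from compound 2 to compound 3, not the same: in compound 3 the fluoro sits on a six-membered aromatic ring of carbon only, para to a large group, whereas in compound 4 it sits on a six-membered aromatic ring of carbon only that is part of a fused or bridged system of two rings, ortho to a large group, meta to a fused ring and para to a fused ring.

The step from compound 1 to compound 4 is expected to be a number 8 percentage points lower from compound 1 to compound 4 (within the scatter), resting on a number 8 percentage points lower from compound 2 to compound 3 (within the scatter), which lay within the scatter. Compound 4 is therefore estimated at 42% in this assay, with a range from 20% to 65%.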

Compound 4, a percentage reported as inhibition, in the whole organism at one dose (the size of the read-out at that dose, not a potency): 79%
Beside the measured number, compound 4's estimate is 37 percentage points below it; the measured number lies above the stated range.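

In this assay, fluoro in place of hydrogen on an aromatic carbon gives a number 29 percentage points higher from compound 1 to compound 4 (beyond the scatter), so on the core of compound 1 this change goes with more inhibition at the one dose given. The same change does not carry over as one fixed step from one core to the other in this series: the same change on two cores in this assay, a number 8 percentage points lower (within the scatter) from compound 2 to compound 3 and a number 29 percentage points higher (beyond the scatter) from compound 1 to compound 4, 37 percentage points apart, beyond the scatter of two such steps This does not show what sets the two steps apart, as the fluoro stands on a ring that is part of a fused system only in compound 4, the two cores also differ, and two pairs give no rule for any further core.

Going by these compounds, it remains open whether the step seen with compound 4 belongs to fluoro itself or would also appear with chloro or methoxy on that same aromatic carbon. Also open, on these data alone, is whether fluoro at that place on the core of compound 2 would follow compound 4 or compound 3, and whether a longer chain would keep the number of compound 4.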